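A few compounds are considered here, and "the series" means these few. Any claim that something is new, unique, unknown or untested is made for them only; others in the source may bear on it.

Measured so far in a functional assay on HeLa cells (Homo sapiens) for cytotoxicity, read by MTT assay, with a stated time of 2 days, tested at 1 uM; a higher number here means a weaker effect of the compound at the concentration tested, a lower number a stronger effect:

compound 1 `CC(=O)c1cc(-c2ccccc2)cc2cc(-c3ccc(F)cc3)[nH]c12` gives 85.1%
compound 2 `CC(=O)c1cc(-c2ccc(F)cc2)cc2cc(-c3ccc(F)cc3)[nH]c12` gives 71.6%
compound 3 `COc1ccc(-c2cc3cc(-c4ccccc4)cc(C(C)=O)c3[nH]2)cc1` gives 61.5%

Within this set, one change recurs. From compound 1 to compound 2 it is fluoro in place of hydrogen on an aromatic carbon, and in this assay it produced a number 13.5 percentage points lower from compound 1 to compound 2 (beyond the scatter). Compound 4 `COc1ccc(-c2cc3cc(-c4ccc(F)cc4)cc(C(C)=O)c3[nH]2)cc1`, not yet measured, carries the same change on the core of compound 3: fluoro in place of hydrogen on an aromatic carbon. The two cores differ by methoxy in place of fluoro on an aromatic carbon; that difference alone gave a number 23.6 percentage points lower from compound 1 to compound 3 (beyond the scatter).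

Within the data shown here, compound 4 is expected to show a step of about a number 11.5 percentage points lower from compound 3 to compound 4 (beyond the scatter), resting on the single precedent from compound 1 to compound 2 (a number 13.5 percentage points lower from compound 1 to compound 2 (beyond the scatter)), with some allowance for the different core. Compound 4 is thus estimated at 50% in this assay, expected between 36% and 64%.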

Compound 4, a percentage reported as activity, at one concentration (the size of the read-out at that concentration, not a potency): 62.9%
The estimate for compound 4 lay 12.9 percentage points below the measured number, and the stated range covers the measured number.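

Fluoro in place of hydrogen gave a number 1.4 percentage points higher from compound 3 to compound 4 (within the scatter), which does not repeat the earlier step: the same change on two cores in this assay, a number 13.5 percentage points lower (beyond the scatter) from compound 1 to compound 2 and a number 1.4 percentage points higher (within the scatter) from compound 3 to compound 4, 14.9 percentage points apart, beyond the scatter of two such steps. Methoxy in place of fluoro gave a number 8.7 percentage points lower from compound 2 to compound 4 (within the scatter), which also differs from its earlier step: the same change on two cores in this assay, a number 23.6 percentage points lower (beyond the scatter) from compound 1 to compound 3 and a number 8.7 percentage points lower (within the scatter) from compound 2 to compound 4, 14.9 percentage points apart, beyond the scatter of two such steps. The two changes therefore do not simply add up across these four compounds, but one pair of cores does not show how either change would behave on a further core.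

The compounds shown leave open what a chloro group, an amine or a carboxylic acid in place of the fluoro would give in this assay. They also leave open whether a longer chain in place of the methyl of the methoxy would alter these steps.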